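Lengthening the Chain on the Sulfonamide Nitrogen of Compound 1

The source may hold more compounds than are shown below. What is called first, only, known or untested is meant among the compounds shown, and "the series" means these compounds.

Of the compounds shown here, three sharing one core have been measured in a functional assay on HepG2 cells for inhibition of squalene monooxygenase (Homo sapiens); a lower number here means a stronger inhibitor, a higher number a weaker inhibitor. Compound 1 `CCN(C/C=C/C#CC(C)(C)C)Cc1cccc(OCCN(C)S(=O)(=O)c2cccs2)c1` gives 60 nM; it has the lowest number of the three, and both of its steps to the other two lie beyond the scatter, so it is the strongest inhibitor in this small set. Compound 2 `CCN(C/C=C/C#CC(C)(C)C)Cc1cccc(OCCN(C)S(=O)(=O)c2ccc(Br)cc2)c1` gives 330 nM, and compound 3 `CCN(C/C=C/C#CC(C)(C)C)Cc1cccc(OCCN(C)S(=O)(=O)c2ccc(Br)s2)c1` gives 390 nM. Every measured step concerns the group on the sulfonyl sulfur: a 5.5-fold higher number from compound 1 to compound 2 (0.74 log units; beyond the scatter), a 6.5-fold higher number from compound 1 to compound 3 (0.81 log units; beyond the scatter), and a 1.2-fold higher number from compound 2 to compound 3 (0.07 log units; within the scatter).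

Compound 4 `CCCN(CCOc1cccc(CN(CC)C/C=C/C#CC(C)(C)C)c1)S(=O)(=O)c1cccs1` keeps the thiophen-2-yl on the sulfonyl sulfur of compound 1 and alters only the chain on the sulfonamide nitrogen: ethyl in place of hydrogen on a saturated chain carbon bound to a sulfonamide nitrogen. Cut one bond further out, the same change reads methyl to propyl. Among the measured compounds shown here, none of the measured steps touches this chain; all of them vary the sulfonyl group instead, so they offer no direct guide to the size or direction of this change in this assay. In the absence of evidence either way, no step beyond the scatter is expected, and compound 4 is estimated at 80 nM, with a range from 30 nM to 250 nM. The step this estimate expects is a 1.3-fold higher number from compound 1 to compound 4 (0.12 log units; within the scatter).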

Compound 4, half-maximal inhibitory concentration: 170 nM
For compound 4 the middle estimate is 2.1-fold (0.33 log units) below the measured one; the measured number falls inside the stated range.
By their numbers in this assay, from the lowest: compound 1; then compounds 4, 2 and 3 (each within the scatter of the next, the first and the last beyond it).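

This chain is not a silent position: in this assay, ethyl in place of hydrogen on a saturated chain carbon bound to a sulfonamide nitrogen, which turns methyl into propyl, gives a 2.8-fold higher number from compound 1 to compound 4 (0.45 log units; beyond the scatter), so the propyl compound is the weaker inhibitor of this pair. Among the compounds shown here, the earlier compounds showed only that the group on the sulfonyl sulfur can change the number, whereas this step shows that the chain on the sulfonamide nitrogen can change it too. Nothing available here explains why the longer chain gives the higher number.

One pair cannot show how the number follows chain length, and an ethyl or butyl chain on this nitrogen, or a propyl chain ending in a hydroxyl group or an amine, would be needed to tell a steady trend from a one-off result. On these data alone, it also remains open whether methyl to propyl gives a step of similar size when 4-bromophenyl or 5-bromothiophen-2-yl sits on the sulfonyl sulfur.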